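This account rests on a few compounds, and the source may have more. Where it says the series, first, only, none or still open, it means among the compounds named here.

Measured compounds:
compound 1 `CCCOC(=O)N1N=C(c2ccccc2)CC1c1cc(OC)c(OC)c(OC)c1` — in a functional assay on HepG2 cells (Homo sapiens) for antiproliferative activity, read by MTT assay, with a stated time of 48 h (on this read-out higher numbers stand for weaker inhibition of growth and lower numbers for stronger inhibition of growth), compound 1 gives > 10000 nM, which is a limit of the assay.
compound 2 `CCCOC(=O)N1N=C(c2cccc(O)c2)CC1c1cc(OC)c(OC)c(OC)c1` — compound 2 gives > 10000 nM, also a limit of the assay.
compound 3 `COC(=O)N1N=C(c2ccccc2)CC1c1ccc(OC)c(O)c1` — compound 3 gives 9810 nM.

Compound 3 is the only one of the three with a number; the difference between its core and the core of compound 2 is not broken down here. Between compound 2 and compound 1 the change is hydrogen in place of hydroxy on an aromatic carbon, and the step is a step that the two limits leave unreadable from compound 2 to compound 1; with two values at the limit of > 10000 nM in this assay, at which 2 of the 3 values shown sit, its size cannot be read.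

Compound 4 `COC(=O)N1N=C(c2ccccc2)CC1c1ccc(OC)cc1` is not yet measured. From compound 3 it differs by hydrogen in place of hydroxy on an aromatic carbon, the same kind of change as from compound 2 to compound 1, though here the place is ortho to a methoxy group as well as meta to a large group. Since the earlier step is unreadable, the expectation rests on compound 3, whose number of 9810 nM lies close to the top of the range this assay reports. Compound 4 is expected to show a step of a 1.5-fold higher number from compound 3 to compound 4 (0.18 log units; within the scatter). The estimate for compound 4 in this assay is 15000 nM, within 5000 nM to 50000 nM.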

Compound 4, concentration for 50% growth inhibition: 12000 nM
Compound 4: the middle estimate sits 1.3-fold (0.10 log units) above what was measured, and the stated range covers the measured number.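

In this assay, hydrogen in place of hydroxy on the core of compound 3 gives a 1.2-fold higher number from compound 3 to compound 4 (0.09 log units; within the scatter), so on this core the hydroxy, ortho to a methoxy group, makes no difference that can be told apart from the scatter of repeated measurements. For the compounds shown here, the same kind of change from compound 2 to compound 1 cannot be read, as both compounds give only a limit of the assay and not a number, which leaves no second step to set beside the first: the limit of > 10000 nM in this assay, at which 2 of the 4 values shown sit. The series therefore offers one readable step on one core, which shows neither that the change carries over to another core nor that it does not.

The compounds shown leave open whether an amine or a carboxylic acid at the place of that hydroxy on the core of compound 3 would give a value beyond the scatter of compound 3 and compound 4. They also leave open whether an amine on the core of compound 1 would bring a readable number.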